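The source may hold more compounds than are shown below. What is called first, only, known or untested is meant among the compounds shown, and "the series" means these compounds.

Compound 1 `Cc1ccc(C(=O)Nc2cn3ncnc3c(O[C@H]3CCN(C(=O)CC(C(F)(F)F)C(F)(F)F)[C@@H](C)C3)c2C)cn1`: 10 mL.min-1.g-1
Compound 2 `Cc1ccc(C(=O)Nc2cn3ncnc3c(CN3CCN(C(=O)C(C)C)[C@@H](C)C3)c2C)cn1`: 240 mL.min-1.g-1
Compound 3 `Cc1ccc(C(=O)Nc2cc(F)cc(CN3CCN(C(=O)C4CCCC4)[C@@H](C)C3)c2C)cn1`: 88 mL.min-1.g-1

In an ADME assay on microsomes from liver (Homo sapiens) for metabolic stability (on this read-out higher numbers stand for fast clearance and lower numbers for slow clearance), compound 1 gives 10 mL.min-1.g-1, the lowest of the three numbers. Compound 3 gives 88 mL.min-1.g-1 and compound 2 gives 240 mL.min-1.g-1, and both gaps to compound 1 lie beyond the scatter. Compound 4 `Cc1ccc(C(=O)Nc2cn3ncnc3c(O[C@@H]3CCN(C(=O)CC(C(F)(F)F)C(F)(F)F)[C@@H](C)C3)c2C)cn1` has not yet been measured in this assay. It differs from compound 1 as follows: the two compounds have the same atoms and bonds and differ only in configuration as drawn: 1 of 2 stereo elements differ; a stereocentre at a saturated ring carbon is drawn S in compound 1 and R in compound 4. Among the measured compounds shown here, no pair of measured compounds here differs in a single place, so there is no directly comparable step to lean on. For a change of configuration alone at one ring carbon, the author expects compound 4 to move little from compound 1, with the step of a 1.5-fold higher number from compound 1 to compound 4 (0.18 log units; within the scatter) not clearly beyond the scatter. Compound 4 is therefore estimated at 15 mL.min-1.g-1, within a range of 6 mL.min-1.g-1 to 40 mL.min-1.g-1 in this assay.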

Compound 4, intrinsic clearance in microsomes: 28 mL.min-1.g-1
The estimate for compound 4 lay 1.9-fold (0.27 log units) below the measured number; the range from low to high includes it.
By their numbers in this assay, from the lowest: compound 1; then compound 4; then compound 3; then compound 2.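

Drawing this saturated ring carbon R rather than S gives, in this assay, a 2.8-fold higher number from compound 1 to compound 4 (0.45 log units; beyond the scatter). Among the compounds shown here, the earlier compounds differed in several places at once, so this is the first change that can be read on its own, and it shows that configuration at this one carbon can shift clearance beyond the scatter, if only modestly. The step belongs to that stereocentre because nothing else changes: the fact that compounds 1 and 4 differ only in the configuration as drawn

The compounds shown leave open what inverting the second stereocentre would do. They also leave open whether the step would persist with a carboxylic acid or a longer chain in place of the group carrying the two trifluoromethyl groups.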